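Moving the chlorine on a triazole-linked aryl group

The source may hold more compounds than are shown below. What is called first, only, known or untested is meant among the compounds shown, and "the series" means these compounds.

Compound 1 `COc1cc(O)c(C(=O)/C=C/c2ccc(OCc3cn(-c4ccc(F)cc4Cl)nn3)c(OC)c2)c(OC)c1` was tested in an ADME assay on Huh-7 cells (Homo sapiens) for cytotoxicity, read by MTT assay, with a stated time of 72 h (on this read-out higher numbers stand for lower toxicity in this test and lower numbers for higher toxicity in this test), a cytotoxicity read-out on Huh-7 cells. In this assay compound 1 gives > 100 ug/mL, which is a limit of the measurement rather than a number. Compound 2 `COc1cc(OC)c2c(=O)cc(-c3ccc(OCc4cn(-c5ccc(F)cc5Cl)nn4)c(OC)c3)oc2c1` carries the same 2-chloro-4-fluorophenyl group on the triazole nitrogen but a different core. In this assay compound 2 gives > 100 ug/mL, again a limit and not a measured number. Across the compounds measured so far, the picture is uniform: the limit of > 100 ug/mL in this assay, at which 2 of the 2 values shown sit, so compound 1 stands at the same place as the only other compound tested, with no ranking possible between them.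

Compound 3 `COc1cc(O)c(C(=O)/C=C/c2ccc(OCc3cn(-c4ccc(F)c(Cl)c4)nn3)c(OC)c2)c(OC)c1` is the next compound. Compared with compound 1 it keeps the same atoms joined differently: 3-chloro-4-fluorophenyl in place of 2-chloro-4-fluorophenyl on an aromatic nitrogen. Among the measured compounds shown here, no step between two measured compounds of this kind has been recorded, so the effect of this change rests on nothing measured. Given that compound 1 sits at the limit > 100 ug/mL in this assay, compound 3 is expected to show no step beyond the usual scatter, a step that the limit leaves unreadable from compound 1 to compound 3. Compound 3 is therefore estimated at 120 ug/mL, within a range from 60 ug/mL to 250 ug/mL, and most likely reported again only as a limit.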

Compound 3, half-maximal cytotoxic concentration: > 100 ug/mL
Compound 3: no number, only a limit; the forecaster's own chance of this, stated with the estimate: 80%; the middle value does not contradict the limit.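

In this assay compound 3 gives > 100 ug/mL as a limit and not as a number. Compound 1 also rests on a limit, so no step can be read between compound 1 and compound 3. The compounds shown leave open whether 3-chloro-4-fluorophenyl and 2-chloro-4-fluorophenyl on the aromatic nitrogen differ at all in cytotoxicity on these cells.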